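Shortening the Chain Between Core and Thiourea

This account rests on a few compounds, and the source may have more. Where it says the series, first, only, none or still open, it means among the compounds named here.

Compound 1 `C/N=C(\S)NCCCCCn1nc(-c2ccccc2)ccc1=O`: 35.3 mg/kg in a functional assay on the whole organism (stomach) with Rattus norvegicus as the target; on this read-out higher numbers stand for an effect only at larger amounts of compound and lower numbers for an effect already at smaller amounts
Compound 2 `CC/N=C(\S)NCCCCCn1nc(-c2ccccc2)ccc1=O`: 51.8 mg/kg
Compound 3 `CC/N=C(/NC#N)NCCCCCCn1nc(-c2ccccc2)ccc1=O`: > 100 mg/kg, a limit of this assay

Compound 2 and compound 1 cannot be told apart, since a 1.5-fold higher number from compound 1 to compound 2 (0.17 log units; within the scatter) lies within the scatter. Compound 3 gave only a limit (the limit of > 100 mg/kg in this assay, at which 1 of the 3 values shown sits). Compound 4 `CC/N=C(\S)NCCCn1nc(-c2ccccc2)ccc1=O` differs from compound 2 by a group of 6 heavy atoms (3 carbon, 2 nitrogen, 1 sulfur; no ring) in place of a group of 8 heavy atoms (5 carbon, 2 nitrogen, 1 sulfur; no ring), on a saturated chain carbon, three bonds along the chain from an aromatic nitrogen. Among the measured compounds shown here, none of the measured steps tests this change: a 1.5-fold higher number from compound 1 to compound 2 (0.17 log units; within the scatter) alters the group on the double-bonded nitrogen, while an at least 2.8-fold higher number from compound 1 to compound 3 (0.45 log units; beyond the scatter) and an at least 1.9-fold higher number from compound 2 to compound 3 (0.28 log units; that floor lies within the scatter) replace the sulfur-bearing group with a larger one. For the measured compounds named here, with no measured step bearing on chain length, no step beyond the scatter is expected, a 1.1-fold higher number from compound 2 to compound 4 (0.03 log units; within the scatter). Compound 4 is therefore estimated at 55 mg/kg, within a range of 20 mg/kg to 150 mg/kg.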

Compound 4, dose for half-maximal effect: > 100 mg/kg
Compound 4: a limit, no number; the forecaster's own chance of this, stated with the estimate: 25%; middle value at least 1.8-fold (0.25 log units) away from the limit.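

Compound 4 gave only a limit, not a number: the limit of > 100 mg/kg in this assay, at which 2 of the 4 values shown sit. Among the compounds shown here, this is the first read on chain length with the thiourea kept, and the shorter chain, three bonds along from an aromatic nitrogen, does not hold the effect at the doses of compounds 1 and 2. The step is an at least 2.8-fold higher number from compound 1 to compound 4 (0.45 log units; beyond the scatter), which clears the scatter, while an at least 1.9-fold higher number from compound 2 to compound 4 (0.28 log units; that floor lies within the scatter) has a floor that does not.

The limit leaves the true size of the loss open. Going by these compounds, whether a longer chain on the same thiourea, or an amine in its place, would keep the effect also stays open.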